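The compounds below may be only part of what the source reports. "The series", "measured", "known", "first", "only" and "open" are said of these compounds alone.

Measured so far:
Compound 1, `CCC(C)n1ccc2cc(/C(C)=C/C(=O)Nc3ccccc3OCCCC(=O)O)ccc21`: 67 nM
Compound 2, `CCCCC(c1ccccc1)n1ccc2cc(/C(C)=C/C(=O)Nc3ccccc3OCCCC(=O)O)ccc21`: 9.8 nM

Going by the values given here, in an assay on Prostate gland for inhibition of steroid 5-alpha-reductase (Rattus norvegicus) (on this read-out lower numbers stand for stronger inhibition and higher numbers for weaker inhibition), compound 2 gives the lowest of the two numbers so far; its only neighbour is compound 1, and the step of a 6.8-fold lower number from compound 1 to compound 2 (0.83 log units; beyond the scatter) separates them. Compound 3, `C/C(=C\C(=O)Nc1ccccc1OCCCC(=O)O)c1ccc2c(ccn2C(CC(C)C)c2ccccc2)c1`, has not yet been measured. It differs from compound 2 by isopropyl in place of propyl on a saturated chain carbon, two bonds along the chain from an aromatic carbon and an aromatic nitrogen, so the same atoms are kept and only the branching of the chain beside the phenyl-bearing carbon moves. Among the compounds with values here, no measured step isolates such a rearrangement: the one step available, a 6.8-fold lower number from compound 1 to compound 2 (0.83 log units; beyond the scatter), swaps a small alkyl for a phenyl-bearing chain, which is a different kind of change, and it only shows that this region tolerates bulk. On that basis compound 3 is expected to stay close to compound 2, with a step of a 1.2-fold higher number from compound 2 to compound 3 (0.09 log units; within the scatter) that need not exceed the scatter. The estimate for compound 3 in this assay is 12 nM, within 4 nM to 35 nM.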

Compound 3, half-maximal inhibitory concentration: 6.3 nM
Compound 3: middle estimate off by 1.9-fold (0.28 log units), on the high side, within the range that was stated.
By their numbers in this assay, from the lowest: compounds 3 and 2 (each within the scatter of the next); then compound 1.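

In this assay, isopropyl in place of propyl on a saturated chain carbon gives a 1.6-fold lower number from compound 2 to compound 3 (0.19 log units; within the scatter) and stays within the scatter, so this rearrangement of the same atoms leaves no reliable difference. The earlier pair showed only that 1-phenylpentyl could replace sec-butyl on the aromatic nitrogen. Now 3-methyl-1-phenylbutyl in that place gives an 11-fold lower number from compound 1 to compound 3 (1.03 log units; beyond the scatter) and is also beyond the scatter, so two differently branched phenyl-bearing chains both improve on sec-butyl. The data shown offer no explanation for this tolerance of branching.

The compounds shown leave open whether the chain end can carry an amine or a hydroxyl group in place of isopropyl, or be cut back to a methyl group. They also leave open whether the phenyl group could give way to a pyridyl or cyclohexyl group.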